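The source may report more compounds than this note shows. Statements on the series, on what has been measured and on what is new or still open speak of the compounds shown alone.

Compound 1 `CCC/C(C)=N\Nc1nc(-c2cccc([N+](=O)[O-])c2)cs1` gives 55 nM in an assay on isolated protein for inhibition of Amine oxidase [flavin-containing] B (Homo sapiens), read by fluorescence, with a stated time of 20 min; on this read-out lower numbers stand for stronger inhibition and higher numbers for weaker inhibition.
Compound 2 `CCC(CC)=NNc1nc(-c2cccc([N+](=O)[O-])c2)cs1` gives 53 nM.
Compound 3 `C/C(CC(C)C)=N/Nc1nc(-c2cccc([N+](=O)[O-])c2)cs1` gives 12 nM.

Compound 3 holds the lowest of the three numbers: the steps of a 4.6-fold lower number from compound 1 to compound 3 (0.66 log units; beyond the scatter) and a 4.4-fold lower number from compound 2 to compound 3 (0.65 log units; beyond the scatter) both lie beyond the scatter, whereas a 1.0-fold lower number from compound 1 to compound 2 (0.02 log units; within the scatter) lies within it. Compound 4 `C=CCC/C(C)=N\Nc1nc(-c2cccc([N+](=O)[O-])c2)cs1` differs from compound 3 by allyl in place of isopropyl on a saturated chain carbon bound to a carbon with a double bond to nitrogen. The measured step that bears on this is a 4.6-fold lower number from compound 1 to compound 3 (0.66 log units; beyond the scatter), where a branch on that chain carbon lowered the number; compound 4 removes the branch again and carries an unbranched chain, as compound 1 does. Compound 4 is therefore expected to show a modest upward step, a 2.9-fold higher number from compound 3 to compound 4 (0.46 log units; beyond the scatter). The estimate for compound 4 is 35 nM, with a range from 15 nM to 90 nM.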

Compound 4, half-maximal inhibitory concentration: 101 nM
Estimate against measurement, compound 4: 2.9-fold (0.46 log units) below; the whole stated range lies below it.
By their numbers in this assay, from the lowest: compound 3; then compounds 2, 1 and 4 (each within the scatter of the next).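

At this place, on a saturated chain carbon bound to a carbon with a double bond to nitrogen, allyl in place of isopropyl gives an 8.4-fold higher number from compound 3 to compound 4 (0.93 log units; beyond the scatter) in this assay, so an unbranched group with the same heavy-atom count does not keep the low number of compound 3. The double bond at the chain end brings no readable difference: a 1.8-fold higher number from compound 1 to compound 4 (0.26 log units; within the scatter) and a 1.9-fold higher number from compound 2 to compound 4 (0.28 log units; within the scatter) both lie within the scatter. Nothing available explains the size of the step from the isopropyl compound. From the compounds shown here alone, it remains open how a longer branched chain or a cyclohexyl group at this place would read, and what an amine on the chain would do.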